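This account rests on a few compounds, and the source may have more. Where it says the series, first, only, none or still open, it means among the compounds named here.

Measured compounds:
- compound 1, `CN(C)CCNc1nc(-c2ccc(NC(=O)Nc3ccccc3Cl)cc2)nc2c(Cl)c(Cl)sc12`, giving 570 nM in a functional assay on HT-29 cells (Homo sapiens) for cytotoxicity, read by MTT assay, with a stated time of 72 h; on this read-out lower numbers stand for stronger inhibition and higher numbers for weaker inhibition
- compound 2, `CCN(CC)CCCNc1nc(-c2ccc(NC(=O)Nc3ccc(F)cc3)cc2)nc2c(Cl)c(Cl)sc12`, giving 350 nM in this assay
- compound 3, `CCN(CC)CCCNc1nc(-c2ccc(NC(=O)Nc3ccc(Cl)cc3)cc2)nc2c(Cl)c(Cl)sc12`, giving 250 nM in this assay

Compound 3 gives the lowest of the three numbers; compound 2 stands nearest to it, within the scatter, while compound 1 is furthest, beyond the scatter. Among the compounds with values here, the one step measured so far in one place, a 1.4-fold lower number from compound 2 to compound 3 (0.15 log units; within the scatter), is small. Compound 4, `CCN(CC)CCCNc1nc(-c2ccc(NC(=O)Nc3ccccc3Cl)cc2)nc2c(Cl)c(Cl)sc12`, differs from compound 3 by 2-chlorophenyl in place of 4-chlorophenyl on an amide-type nitrogen. Within the data shown here, no measured pair isolates this change. Among the measured compounds shown here, compound 1 already carries the 2-chlorophenyl group, but it also differs from compound 3 in the amine side chain, so the two values show only that compound 1 sits beyond the scatter from compound 3. On that basis a modest rise in number is expected for compound 4, a 1.8-fold higher number from compound 3 to compound 4 (0.26 log units; within the scatter), though it may well fall within the scatter. Compound 4 is thus estimated at 450 nM, with a range from 200 nM to 1000 nM.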

Compound 4, half-maximal inhibitory concentration: 410 nM
For compound 4 the middle estimate is 1.1-fold (0.04 log units) above the measured one; low and high end bracket the measured number.
By their numbers in this assay, from the lowest: compounds 3, 2, 4 and 1 (each within the scatter of the next, the first and the last beyond it).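

In this assay, 2-chlorophenyl in place of 4-chlorophenyl on the amide-type nitrogen, with the amine side chain held constant, gives a 1.6-fold higher number from compound 3 to compound 4 (0.21 log units; within the scatter), so this change of chlorine position has no effect that can be told from scatter. Against the fluorinated group, the same 2-chlorophenyl gives a 1.2-fold higher number from compound 2 to compound 4 (0.07 log units; within the scatter), which leaves the three aryl groups on this nitrogen unseparated. On the side chain, (diethylamino)methyl in place of dimethylamino gives a 1.4-fold lower number from compound 1 to compound 4 (0.14 log units; within the scatter), so the gap beyond the scatter between compound 1 and compound 3 now divides into two steps that each lie within it, and no evidence is available to explain any of these steps.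

The compounds shown leave open whether a methoxy group or a carboxylic acid in place of the chlorine would move the number beyond the scatter. They also leave open how a cyclic amine such as morpholine at the end of the side chain would compare.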